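Anilide swap on a weakly cytotoxic scaffold

A few compounds are considered here, and "the series" means these few. Any claim that something is new, unique, unknown or untested is made for them only; others in the source may bear on it.

Measured in an ADME assay on SW480 cells (Homo sapiens) for cytotoxicity, read by MTT assay, with a stated time of 72 h; on this read-out higher numbers stand for weaker inhibition and lower numbers for stronger inhibition:
Compound 1 `O=C(Nc1ccccc1)c1cccc(/C=C2\CC(=O)N(c3ccccc3)C2=O)c1`: > 100000 nM, which is a limit of the assay.
Compound 2 `Cc1ccc(N2C(=O)C/C(=C\c3cccc(C(=O)Nc4cccc(F)c4)c3)C2=O)cc1`: 96900 nM.

Among the compounds with values here, compound 2 holds the only number in this assay; the other entry is a limit, (the limit of > 100000 nM in this assay, at which 1 of the 2 values shown sits). Compound 3 `COc1ccc(NC(=O)c2cccc(/C=C3\CC(=O)N(c4ccc(C)cc4)C3=O)c2)cc1` differs from compound 2 by 4-methoxyphenyl in place of 3-fluorophenyl on an amide-type nitrogen. Within the data shown here, no step between two measured compounds is available, so the data give no guide to the size of this change. The step from compound 2 to compound 3 is expected to stay within the scatter, a 1.0-fold higher number from compound 2 to compound 3 (0.01 log units; within the scatter). Compound 3 is therefore estimated at 100000 nM, in a range from 40000 nM to 250000 nM.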

Compound 3, half-maximal inhibitory concentration: 93000 nM
The estimate for compound 3 lay 1.1-fold (0.03 log units) above the measured number, within the range that was stated.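

In this assay, within the data shown here, this is the first measured step at this amide-type nitrogen, and it is small: a 1.0-fold lower number from compound 2 to compound 3 (0.02 log units; within the scatter). Replacing 3-fluorophenyl with 4-methoxyphenyl adds a hydrogen-bond acceptor, yet the two compounds stay within the scatter of each other. Their numbers also lie close to the limit of the assay: the limit of > 100000 nM in this assay, at which 1 of the 3 values shown sits.

From the compounds shown here alone, what a short alkyl chain, or a phenyl ring carrying an amine or a carboxylic acid, would do on this nitrogen remains open. So does whether any group here can bring the number far below those of compound 2 and compound 3.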